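Methyl in place of methoxy on compound 1

This account rests on a few compounds, and the source may have more. Where it says the series, first, only, none or still open, it means among the compounds named here.

Compound 1 `COc1ccc(-n2cc(CSC(=S)N3CCN(C(=O)OC(C)(C)C)CC3)nn2)cc1` is the reference point of this pair. In a functional assay on PC-3 cells (Homo sapiens) for inhibition, read by MTT assay, with a stated time of 72 h (a higher number here means a weaker inhibitor, a lower number a stronger inhibitor), compound 1 reaches only the limit of the assay, > 128000 nM, and no number is known for it. That reading sits at the limit of > 128000 nM in this assay, at which 1 of the 2 values shown sits. For the measured compounds named here, compound 2 `O=C(OCc1ccccc1)N1CCN(C(=S)SCc2cn(Cc3ccccc3F)nn2)CC1` differs from compound 1 in more than one place, so no single step connects the two; in this assay compound 2 gives 68300 nM, and the pair shows only that both sit at the weak end of what this assay can report.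

Compound 3 `Cc1ccc(-n2cc(CSC(=S)N3CCN(C(=O)OC(C)(C)C)CC3)nn2)cc1` differs from compound 1 by one change, (methyl in place of methoxy on an aromatic carbon), methyl in place of methoxy on an aromatic carbon. Going by the values given here, no measured step of this kind exists, so the size of the step in this assay cannot be read from data. Starting from a limit, the step from compound 1 to compound 3 is expected to be a step that the limit leaves unreadable from compound 1 to compound 3, none beyond the scatter in either direction. For compound 3 the estimate is 130000 nM, expected to fall between 50000 nM and 300000 nM. A further limit reading for compound 3 is expected about as often as a number.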

Compound 3, half-maximal inhibitory concentration: > 128000 nM
Compound 3: only a limit was reported (the forecaster's own chance of this, stated with the estimate: 55%); the middle value does not contradict the limit.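

No step can be read from compound 1 to compound 3: in this assay both compounds give only limits, not numbers, and the change of methoxy to methyl therefore has no readable size: the limit of > 128000 nM in this assay, at which 2 of the 3 values shown sit.

The compounds shown leave open whether methyl in place of methoxy on an aromatic carbon changes inhibition at all, and by how much, on a compound that gives a number in this assay.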